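The source may report more compounds than this note shows. Statements on the series, on what has been measured and on what is new or still open speak of the compounds shown alone.

Among the measured compounds shown here, compound 2 `Nc1ccc2cccc(OCC3CCC3)c2n1` holds the only number in an assay on cells with melanin-concentrating hormone receptor 1 (Homo sapiens) as the target, read by radioligand binding (a lower number here means a stronger inhibitor, a higher number a weaker inhibitor), where compound 2 gives 432 nM. Compound 1 `CC(C)OCCOc1cccc2ccc(N)nc12` reaches only a limit in this assay, > 2000 nM (the limit of > 2000 nM in this assay, at which 1 of the 2 values shown sits). For the measured compounds named here, the one measured step is an at least 4.6-fold lower number from compound 1 to compound 2 (0.66 log units; beyond the scatter), which exchanged an ether-bearing chain for a ring of carbon only. Compound 3 `Nc1ccc2cccc(OCC3CCOC3)c2n1` differs from compound 2 by oxolan-3-yl in place of cyclobutyl on a saturated chain carbon bound to an oxygen on an aromatic ring. Because an at least 4.6-fold lower number from compound 1 to compound 2 (0.66 log units; beyond the scatter) went with the loss of an ether oxygen and the oxolane brings one back inside a ring, compound 3 is expected to show a modest rise, a step of a 1.7-fold higher number from compound 2 to compound 3 (0.24 log units; within the scatter) in this assay, with an estimated 750 nM and a range from 250 nM to 2200 nM.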

Compound 3, half-maximal inhibitory concentration: 115 nM
Estimate against measurement, compound 3: 6.5-fold (0.81 log units) above; measured number outside the range, below it.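

In this assay the oxygen that enters with oxolan-3-yl does not weaken the compound: a 3.8-fold lower number from compound 2 to compound 3 (0.57 log units; beyond the scatter) comes with this change on a saturated chain carbon bound to an oxygen on an aromatic ring. Against the open isopropoxymethyl chain, an at least 17-fold lower number from compound 1 to compound 3 (1.24 log units; beyond the scatter) shows that the presence of an ether oxygen alone does not set the number here. Compound 1 stands only at a limit: the limit of > 2000 nM in this assay, at which 1 of the 3 values shown sits.

On these data alone, whether the gain follows the oxygen or the five-membered ring stays open, as oxolan-3-yl differs from cyclobutyl in both. A cyclopentyl group or a pyrrolidine amine at this place would separate the two.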